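Compound 3 to compound 4: an aryl swap

The source may hold more compounds than are shown below. What is called first, only, known or untested is meant among the compounds shown, and "the series" means these compounds.

For the measured compounds named here, in a functional assay on ECa-109 cells (Homo sapiens) for cytotoxicity, read by MTT assay, with a stated time of 48 h (a lower number here means a stronger inhibitor, a higher number a weaker inhibitor), compound 3 `COc1cc(-n2c(-c3ccc(Br)cc3)cn(C(C)=O)c2=O)cc(OC)c1OC` gives 3800 nM as the only number so far. Compound 1 `COc1ccc(-c2cn(C(=O)Nc3cc(OC)c(OC)c(OC)c3)c(=O)n2-c2cc(OC)c(OC)c(OC)c2)cc1` reads > 50000 nM and this is a limit, not a number. Compound 2 `COc1ccc(-c2cn(C(=O)Nc3cc(OC)c(OC)c(OC)c3)c(=O)n2-c2cc(OC)c(OC)c(OC)c2)cc1O` reads > 50000 nM and this too is a limit. Going by the values given here, the one measured step that the two limits leave unreadable from compound 1 to compound 2 has no readable size and concerns a different change, so it does not bear on this one. The change to compound 4 `COc1cc(-n2c(-c3ccc(F)cc3F)cn(C(C)=O)c2=O)cc(OC)c1OC` is 2,4-difluorophenyl in place of 4-bromophenyl on an aromatic carbon on the shared core. Among the compounds with values here, no measured step covers such a swap, so the expectation rests on compound 3 at 3800 nM alone, with no shift beyond the scatter in this assay foreseen. The expected outcome is a 1.1-fold higher number from compound 3 to compound 4 (0.02 log units; within the scatter) as the step. The estimated value for compound 4 is 4000 nM with 1200 nM to 15000 nM as the expected range.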

Compound 4, half-maximal inhibitory concentration: > 50000 nM
Compound 4: only a limit was reported; the forecaster's own chance of this, stated with the estimate: 10%; at least 12-fold (1.09 log units) between middle value and limit.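

In this assay, for the compounds shown here, the aryl group on this aromatic carbon proves decisive, with 2,4-difluorophenyl in place of 4-bromophenyl giving an at least 13-fold higher number from compound 3 to compound 4 (1.11 log units; beyond the scatter), the first readable step. Among the compounds shown, a number on the shared core survives only with 4-bromophenyl at this position. Compound 4 reads > 50000 nM, which is a limit, so the step gives only a minimum size: the limit of > 50000 nM in this assay, at which 3 of the 4 values shown sit.

From the compounds shown here alone, whether the loss follows from removing the bromine or from adding the two fluorines remains open. A plain phenyl, or a chlorine or an amine in place of the bromine, would bear on that question.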